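Ethyl for Methyl on the Piperazine Nitrogen

The source may report more compounds than this note shows. Statements on the series, on what has been measured and on what is new or still open speak of the compounds shown alone.

Compound 1 `COc1cc2c(cc1N1C[C@@H](C)N(C)[C@@H](C)C1)N(C(=O)c1ccc(-c3cccc(C)n3)c3ccccc13)CC2` gives 100 nM in an assay on isolated protein for binding affinity to 5-hydroxytryptamine receptor 1D (Homo sapiens) (on this read-out lower numbers stand for stronger inhibition and higher numbers for weaker inhibition), the lower of the two numbers recorded. Compound 2 `COc1cc2c(cc1N1C[C@@H](C)N[C@@H](C)C1)N(C(=O)c1ccc(-c3ccc(N4CCCC4=O)nc3C)cc1)CC2` gives 398 nM in this assay, a gap beyond the usual scatter. Compound 3 `CCN1[C@H](C)CN(c2cc3c(cc2OC)CCN3C(=O)c2ccc(-c3cccc(C)n3)c3ccccc23)C[C@@H]1C` has not yet been measured; it differs from compound 1 by methyl in place of hydrogen on a saturated chain carbon bound to an amine nitrogen in a ring. For the measured compounds named here, no step between measured compounds is available to guide the change, so only a small shift, if any, is expected: a 1.3-fold higher number from compound 1 to compound 3 (0.10 log units; within the scatter). Compound 3 is estimated at 125 nM, within a range from 50 nM to 320 nM.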

Compound 3, inhibition constant: 126 nM
Compound 3: the middle estimate sits 1.0-fold (0.00 log units) below what was measured, within the range that was stated.
By their numbers in this assay, from the lowest: compounds 1 and 3 (each within the scatter of the next); then compound 2.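

In this assay, for the compounds shown here, the exchange of 3,4,5-trimethylpiperazin-1-yl for 4-ethyl-3,5-dimethylpiperazin-1-yl gives the only step read at this position, a 1.3-fold higher number from compound 1 to compound 3 (0.10 log units; within the scatter), on the core of compound 1. Methyl to ethyl at this place therefore leaves binding indistinguishable from that of compound 1. Nothing available explains this result.

On these data alone, whether a longer chain such as propyl, or a carboxylic acid, would be accommodated as well at this place remains open. As far as these compounds go, whether methyl to ethyl behaves the same way on other cores also remains open.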